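Extending the hydroxycarbamoyl chain of compound 2

The source may report more compounds than this note shows. Statements on the series, on what has been measured and on what is new or still open speak of the compounds shown alone.

Measured in a functional assay on MCF7 cells (Homo sapiens) for inhibition, read by MTT assay, with a stated time of 72 h; a higher number here means a weaker inhibitor, a lower number a stronger inhibitor:
- compound 1 `CNC(=O)CCCCCCCn1nc(-c2cnc3[nH]ccc3c2)c2c(N)ncnc21`: 7570 nM
- compound 2 `Nc1nc2cc(-c3nn(CCCC(=O)NO)c4ncnc(N)c34)ccc2o1`: > 50000 nM
- compound 3 `Nc1ncnc2c1c(-c1cnc3[nH]ccc3c1)nn2CCCCCC(=O)NO`: > 150000 nM

In this assay compound 2 gives > 50000 nM, which is a limit and not a number. Compound 3 gives > 150000 nM, which is also a limit. Only compound 1 has a measured number, 7570 nM.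

Compound 4 `Nc1nc2cc(-c3nn(CCCCCCCCCC(=O)NO)c4ncnc(N)c34)ccc2o1` has 6-(hydroxycarbamoyl)hexyl in place of hydroxycarbamoyl on a saturated chain carbon, three bonds along the chain from an aromatic nitrogen. Among the compounds with values here, one measured step bears on this change: an at least 19-fold higher number from compound 1 to compound 3 (1.29 log units; beyond the scatter). That large step shortens the group, so the lengthening in compound 4 points the opposite way, towards a lower number. The step also replaces the 2-(methylcarbamoyl)ethyl group, so it is only a loose guide, and the expected range stays wide. A large expected step is therefore estimated: an at least 12-fold lower number from compound 2 to compound 4 (1.09 log units; beyond the scatter). For compound 4 the estimate is 4000 nM, with an expected range from 400 nM to 30000 nM.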

Compound 4, half-maximal inhibitory concentration: > 50000 nM
Compound 4: a limit, no number (the forecaster's own chance of this, stated with the estimate: 15%); at least 12-fold (1.09 log units) between middle value and limit.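

In this assay compound 4 gives > 50000 nM, which is a limit and not a number. Compound 2 also stands at a limit, and the step from compound 2 to compound 4 cannot be read. The compounds shown leave open whether the longer chain of compound 4 changes inhibition at all.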